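A pyridin-2-yl group on the ring amine of compound 2

The source may hold more compounds than are shown below. What is called first, only, known or untested is meant among the compounds shown, and "the series" means these compounds.

Measured so far in an ADME assay on microsomes from liver (Mus musculus) for metabolic stability, read by LC-MS, with a stated time of 10 min; on this read-out lower numbers stand for a less stable compound and higher numbers for a more stable compound
compound 1 `CC(C)N1CCN(c2cccc3c2C[C@H](CN(C)[C@H]2CCCc4cccnc42)NC3)CC1` gives 15.1%
compound 2 `CN(C[C@H]1Cc2c(cccc2N2CCNCC2)CN1)[C@H]1CCCc2cccnc21` gives 19.9%

In this assay, for the measured compounds named here, compound 2 stands level with compound 1, its only measured neighbour, since the two values lie within the scatter of each other. The next structure, compound 3 `CN(C[C@H]1Cc2c(cccc2N2CCN(c3ccccn3)CC2)CN1)[C@H]1CCCc2cccnc21`, differs from compound 2 at the ring nitrogen that carries a hydrogen: pyridin-2-yl in place of hydrogen on an amine nitrogen in a ring. Going by the values given here, one measured step bears on this place, a number 4.8 percentage points higher from compound 1 to compound 2 (within the scatter), which is hydrogen in place of isopropyl on that same amine nitrogen. On this single step, no change beyond the scatter is expected in this assay, although the step offers no aromatic group as a guide. The expected outcome is estimated as a number 4.9 percentage points lower from compound 2 to compound 3 (within the scatter), and the wide range reflects this thin evidence. For compound 3 the estimated value is 15%, with an expected range from 5% to 32%.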

Compound 3, percent of the compound remaining: 46.1%
Estimate against measurement, compound 3: 31.1 percentage points below; measured number outside the range, above it.
By their numbers in this assay, from the lowest: compounds 1 and 2 (each within the scatter of the next); then compound 3.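

In this assay the ring amine nitrogen turned out to be a place where the read-out can move beyond the scatter: pyridin-2-yl on it gives a number 26.2 percentage points higher from compound 2 to compound 3 (beyond the scatter) when set against hydrogen, whereas hydrogen and isopropyl had stayed within the scatter of each other. Against isopropyl the same group gives a number 31 percentage points higher from compound 1 to compound 3 (beyond the scatter) on that nitrogen, so among the three groups seen there, only the aromatic one stands apart. No measurement here gives a reason for this rise.

The compounds shown leave open whether the ring nitrogen of pyridin-2-yl counts or whether a plain phenyl group on the same amine nitrogen would read alike. Also open, as far as these compounds go, is how a pyrimidin-2-yl or an acetyl group there would read in this assay on the shared core.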